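Quinazoline series: methylsulfanyl for methoxy on the benzyl ring

The source may report more compounds than this note shows. Statements on the series, on what has been measured and on what is new or still open speak of the compounds shown alone.

Measured so far in a functional assay on HTB-54 cells (Homo sapiens) for cytotoxicity, read by MTT assay, with a stated time of 72 h; on this read-out lower numbers stand for stronger inhibition of growth and higher numbers for weaker inhibition of growth:
compound 1, `COc1ccc(CNc2nc(SC)nc3ccccc23)cc1`, gives > 100000 nM.
compound 2, `COc1ccc(CNc2nc(S)nc3ccccc23)cc1`, gives 45500 nM.

For compound 1 the reading is only a limit of the limit of > 100000 nM in this assay, at which 1 of the 2 values shown sits, not a number. Compound 2 gives 45500 nM in this assay. Among the compounds with values here, the one measured step is an at least 2.1-fold lower number from compound 1 to compound 2 (0.34 log units; beyond the scatter), a change on the sulfur of the shared core that is not the change now in question.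

Compound 3, `CSc1ccc(CNc2nc(SC)nc3ccccc23)cc1`, has not been measured. It differs from compound 1 by methylsulfanyl in place of methoxy on an aromatic carbon. Within the data shown here, nothing measured bears directly on this change: the only step so far concerns the sulfur substituent of the core, not the group on the benzyl ring. Among the measured compounds shown here, with compound 1 sitting at a limit, the direction of the change can only be an expectation drawn from that limit, and no measured step supports a move to a stronger inhibition of growth.

Compound 3 is expected to give about 100000 nM in this assay, within a range of 30000 nM to 300000 nM, and may again report only a limit. The estimated step is a number no higher from compound 1 to compound 3 (the limit leaves the size open).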

Compound 3, concentration for total growth inhibition: 44500 nM
Estimate against measurement, compound 3: 2.2-fold (0.35 log units) above; the range from low to high includes it.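

In this assay, the group on the benzyl ring, para to a large group, now proves able to shift the read-out: methylsulfanyl in place of methoxy on an aromatic carbon gives an at least 2.2-fold lower number from compound 1 to compound 3 (0.35 log units; beyond the scatter), whereas the earlier step concerned only the sulfur substituent of the shared core. The two groups match in every count computed for them, namely heavy atoms, hydrogen-bond donors and hydrogen-bond acceptors, so these counts do not separate the pair. The step can be read only as a minimum, and its true size stays unknown, because compound 1 stands at a limit and not at a number: the limit of > 100000 nM in this assay, at which 1 of the 3 values shown sits.

The compounds shown leave open whether this shift is particular to methylsulfanyl or would also follow from other groups at this place, such as an amine, a halogen like chlorine or a longer chain like ethylsulfanyl. They also leave open whether methylsulfanyl on the benzyl ring would act in the same direction on the core of compound 2, which carries hydrogen in place of methyl on the sulfur.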